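Two inverted ring stereocentres on a slowly cleared compound

The source may hold more compounds than are shown below. What is called first, only, known or untested is meant among the compounds shown, and "the series" means these compounds.

In an ADME assay on liver for metabolic stability, with Liver microsome (Homo sapiens) as the target, read by LC-MS, using microsomes (on this read-out higher numbers stand for fast clearance and lower numbers for slow clearance), three compounds on one shared core have been read. Compound 1 (`CC(C)(C)OC[C@@H](O)C(=O)N1[C@H](C(=O)NCc2cc(Cl)ccc2-n2cnnn2)C[C@@H]2C[C@@H]21`) gives 21 mL.min-1.g-1 there. Compound 3 (`CCCC[C@@H](O)C(=O)N1[C@@H]2C[C@@H]2C[C@H]1C(=O)NCc1cc(Cl)ccc1-n1cnnn1`) gives 89 mL.min-1.g-1 there. Compound 2 (`O=C(NCc1cc(Cl)ccc1-n1cnnn1)[C@@H]1C[C@H]2C[C@H]2N1C(=O)[C@H](O)c1ccccc1`) is reported only as a limit: it stands at the limit of < 15 mL.min-1.g-1 in this assay, at which 1 of the 3 values shown sits, and its entry reads < 15 mL.min-1.g-1 with no exact number.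

Compound 4 (`O=C(NCc1cc(Cl)ccc1-n1cnnn1)[C@@H]1C[C@@H]2C[C@@H]2N1C(=O)[C@H](O)c1ccccc1`) is a stereoisomer of compound 2 (the two compounds have the same atoms and bonds and differ only in configuration as drawn: 2 of 4 stereo elements differ; a stereocentre at a saturated ring carbon is drawn R in compound 2 and S in compound 4; a stereocentre at a saturated ring carbon is drawn R in compound 2 and S in compound 4). The atoms and bonds are the same, and two stereocentres at saturated ring carbons are drawn R in compound 2 and S in compound 4.

Within the data shown here, only one measured step starts from compound 2, an at least 5.9-fold higher number from compound 2 to compound 3 (0.77 log units; beyond the scatter) in this assay. That step puts butyl in place of phenyl and lies beyond the scatter, but it does not concern the ring stereocentres. Among the measured compounds shown here, compound 4 keeps the phenyl of compound 2, so that step gives no size for this inversion, and no measured pair isolates such a change. No step beyond the scatter is therefore expected with any confidence, only a possible small rise, and the estimated step is an at least 1.2-fold higher number from compound 2 to compound 4 (0.07 log units; that floor lies within the scatter) in this assay. The estimate for compound 4 is 18 mL.min-1.g-1 (expected range 9 mL.min-1.g-1 to 45 mL.min-1.g-1).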

Compound 4, intrinsic clearance in microsomes in the Liver microsome assay: < 16 mL.min-1.g-1
Compound 4 gave a limit, no number (the forecaster's own chance of this, stated with the estimate: 45%); at least 1.1-fold (0.05 log units) between middle value and limit.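

Compound 4, with two ring stereocentres inverted relative to compound 2, is again reported only as a limit in the Liver microsome assay: the limit of < 16 mL.min-1.g-1 in the Liver microsome assay, at which 1 of the 4 values shown sits.

Among these compounds, the step between these two compounds in the Liver microsome assay cannot be read, so the inversion has no measured size there, and the one readable new step, with phenyl in place of (tert-butoxy)methyl, is an at least 1.3-fold lower number from compound 1 to compound 4 (0.11 log units; that floor lies within the scatter). In a physicochemical assay for solubility, measured as kinetic solubility, at pH 6.8 (on this read-out higher numbers stand for higher solubility and lower numbers for lower solubility), compound 2 gives 100000 nM and compound 4 gives 97000 nM, which is a 1.0-fold lower number from compound 2 to compound 4 (0.01 log units; within the scatter), so this read-out does not separate the two stereoisomers.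

The compounds shown leave open whether the inversion changes clearance at all in the Liver microsome assay, a question that could be read only on a pair with exact numbers, such as the butyl of compound 3 carried on both ring configurations. Also open, from the compounds shown here alone, is how an amine or a longer chain in place of the phenyl would read on either ring configuration.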